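Swapping one ring group on a shared core

The source may hold more compounds than are shown below. What is called first, only, known or untested is meant among the compounds shown, and "the series" means these compounds.

Values measured in an ADME assay on microsomes from liver (Rattus norvegicus) for metabolic stability (on this read-out lower numbers stand for a shorter-lived compound and higher numbers for a longer-lived compound), so far
- Compound 1 (`CC(C)C(Cc1ncc[nH]1)c1ccc(-c2ccc3cccc(F)c3c2)[nH]c1=O`) gives < 0.0667 h as a limit of the assay, not a number
- Compound 2 (`CC(C)C(Nc1nnc[nH]1)c1ccc(-c2ccc3cccc(F)c3c2)[nH]c1=O`) gives 1.29 h
- Compound 3 (`CC(C)C(c1ccc(-c2ccc3cccc(F)c3c2)[nH]c1=O)N1CCCCC1=O`) gives 0.102 h

Of the two actual numbers, compound 3 has the lower one. Compound 4 (`CC(C)C(c1ccc(-c2ccc3cccc(F)c3c2)[nH]c1=O)N1CCN/C1=N\C#N`) differs from compound 3 in one place (a group of 8 heavy atoms (4 carbon, 4 nitrogen; one five-membered non-aromatic ring with 2 hetero atoms) in place of a group of 7 heavy atoms (5 carbon, 1 nitrogen, 1 oxygen; one six-membered non-aromatic ring with 1 hetero atom), on a saturated chain carbon bound to an aromatic carbon and a saturated chain carbon). The step of an at least 19-fold higher number from compound 1 to compound 2 (1.28 log units; beyond the scatter) is large, and so is a 13-fold lower number from compound 2 to compound 3 (1.10 log units; beyond the scatter) in the other direction, whereas an at least 1.5-fold higher number from compound 1 to compound 3 (0.18 log units; that floor lies within the scatter) has a floor within the scatter. The entering group is rich in nitrogen, like that of compound 2 (1.29 h), so a moderate rise in this assay is expected, not a full return. The expected change is a 3.9-fold higher number from compound 3 to compound 4 (0.59 log units; beyond the scatter) as an estimate only. Compound 4 is estimated at 0.4 h (0.1 h to 1.5 h).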

Compound 4, half-life: 0.327 h
Estimate against measurement, compound 4: 1.2-fold (0.09 log units) above, and the stated range covers the measured number.
By their numbers in this assay, from the lowest: compound 3; then compound 4; then compound 2. At a limit, below all of these: compound 1.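

On the saturated chain carbon, a five-membered non-aromatic ring group in place of 2-oxopiperidin-1-yl gives a 3.2-fold higher number from compound 3 to compound 4 (0.51 log units; beyond the scatter), so a non-aromatic ring here can reach a middle level in this assay. That level still falls short of the aromatic ring group of compound 2, with a 3.9-fold lower number from compound 2 to compound 4 (0.60 log units; beyond the scatter). The comparison with the imidazole compound, an at least 4.9-fold higher number from compound 1 to compound 4 (0.69 log units; beyond the scatter), gives only a floor, since compound 1 stands at a limit: the limit of < 0.0667 h in this assay, at which 1 of the 4 values shown sits.

On these data alone, it remains open whether the ring or its nitrile accounts for the rise, and how a simple amine or a carboxylic acid would fare at this place in this assay.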